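Swapping One Ring Pair for Another

A few compounds are considered here, and "the series" means these few. Any claim that something is new, unique, unknown or untested is made for them only; others in the source may bear on it.

Values in a functional assay on K562 cells (Homo sapiens) for inhibition, with a stated time of 72 h; on this read-out higher numbers stand for weaker inhibition and lower numbers for stronger inhibition
compound 1 `NC1CCC(Nc2nc(NCc3ccc(Br)cc3)c3ncn(C4CCCC4)c3n2)CC1` gives 1170 nM
compound 2 `NC1CCC(Nc2nc(NCc3ccc(-n4cccn4)cc3)c3ncn(C4CCCC4)c3n2)CC1` gives 119 nM

Of these two, compound 2 stands lowest at 119 nM and so inhibits more strongly. Compound 3 `NC1CCC(Nc2nc(NCc3ccc(-c4ccsc4)nc3)c3ncn(C4CCCC4)c3n2)CC1` is not yet measured. It differs from compound 2 as follows: 6-(thiophen-3-yl)pyridin-3-yl in place of 4-(1H-pyrazol-1-yl)phenyl on a saturated chain carbon bound to a nitrogen on an aromatic ring. Among the compounds with values here, the only measured guide is a 9.8-fold lower number from compound 1 to compound 2 (0.99 log units; beyond the scatter), when 1H-pyrazol-1-yl replaced bromo. That step involved a different exchange, whereas here a five-membered and a six-membered aromatic ring remain. No step beyond the scatter is therefore expected in this assay, and the estimate is a 1.3-fold higher number from compound 2 to compound 3 (0.10 log units; within the scatter). For compound 3 the expected value is 150 nM, with an estimated range of 45 nM to 500 nM.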

Compound 3, half-maximal inhibitory concentration: 150 nM
Estimate against measurement, compound 3: no gap at the digits printed; low and high end bracket the measured number.
By their numbers in this assay, from the lowest: compounds 2 and 3 (each within the scatter of the next); then compound 1.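

In this assay, the pair of aromatic rings on the saturated chain carbon can be exchanged for one carrying a sulfur in the five-membered ring and a nitrogen in the six-membered ring, with a 1.3-fold higher number from compound 2 to compound 3 (0.10 log units; within the scatter) staying within the scatter. The advantage over the bromo compound persists, with a 7.8-fold lower number from compound 1 to compound 3 (0.89 log units; beyond the scatter) lying beyond the scatter. No measurement shown explains why these two ring pairs give matching numbers. As far as these compounds go, whether a saturated ring such as morpholine could stand in place of the aromatic pair and hold this level remains open.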